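Replacing 2-methoxyphenyl with (4-chlorophenyl)amino on the shared core

A few compounds are considered here, and "the series" means these few. Any claim that something is new, unique, unknown or untested is made for them only; others in the source may bear on it.

In a functional assay on HL-60 cells (Homo sapiens) for antiproliferative activity, read by MTT assay, with a stated time of 72 h (a lower number here means a stronger inhibitor, a higher number a weaker inhibitor), compound 1 `COc1cc(C(=O)c2sc3ccccc3c2-c2ccc(F)cc2)cc(OC)c1OC` gives 3200 nM, compound 2 `COc1cc(C(=O)c2sc3ccccc3c2-c2ccc(Cl)cc2)cc(OC)c1OC` gives 3300 nM and compound 3 `COc1ccccc1-c1c(C(=O)c2cc(OC)c(OC)c(OC)c2)sc2ccccc12` gives 2900 nM. Compound 3 therefore stands level with the other two, within the scatter of both. The next compound, compound 4 `COc1cc(C(=O)c2sc3ccccc3c2Nc2ccc(Cl)cc2)cc(OC)c1OC`, carries (4-chlorophenyl)amino in place of 2-methoxyphenyl on an aromatic carbon. The measured steps at this place are a 1.1-fold lower number from compound 1 to compound 3 (0.04 log units; within the scatter) and a 1.1-fold lower number from compound 2 to compound 3 (0.06 log units; within the scatter), and the halogen exchange is a 1.0-fold higher number from compound 1 to compound 2 (0.01 log units; within the scatter). All three stay within the scatter. None of them introduces an amino group, so the data give no direct measure of that part of the change. The nearest guide is compound 2 at 3300 nM, which has the same 4-chlorophenyl group without the amino group. No step beyond the scatter is therefore expected in this assay, in either direction, and the expected step is a 1.5-fold lower number from compound 3 to compound 4 (0.16 log units; within the scatter). For compound 4 the estimate is 2000 nM, with an expected range from 300 nM to 8000 nM.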

Compound 4, half-maximal inhibitory concentration: 5400 nM
Beside the measured number, compound 4's estimate is 2.7-fold (0.43 log units) below it, and the stated range covers the measured number.
By their numbers in this assay, from the lowest: compounds 3, 1, 2 and 4 (each within the scatter of the next).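

Going by these compounds alone, compound 4 is the first compound here with an amino group between the shared core and the aryl ring, and in this assay all three new steps stay within the scatter: a 1.9-fold higher number from compound 3 to compound 4 (0.27 log units; within the scatter), a 1.6-fold higher number from compound 2 to compound 4 (0.21 log units; within the scatter) and a 1.7-fold higher number from compound 1 to compound 4 (0.23 log units; within the scatter). The step from compound 2 is the closest view of the amino group itself, since the 4-chlorophenyl group is present on both sides of it, and inserting that link moves the number no further than the scatter at this position. Nothing given here accounts for these numbers.

The compounds shown leave open whether the amino link would behave in the same way with 2-methoxyphenyl or 4-fluorophenyl on it. They also leave open whether an amide link, a piperazine or a carboxylic acid at this place would give a step beyond the scatter.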